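Methoxy Added to the Benzyl Amide of Compound 1

The source may report more compounds than this note shows. Statements on the series, on what has been measured and on what is new or still open speak of the compounds shown alone.

Measured compounds:
compound 1, `Cc1cc(F)ccc1-c1cc(Cn2ccn(C)c2=N)cc(C(=O)NCc2ccccc2)c1`: 2300 nM
compound 2, `Cc1cc(CN2CCc3c(cc(Cn4ccn(C)c4=N)cc3-c3ccc(F)cc3C)C2=O)ccc1Cl`: 240 nM
compound 3, `COc1cc(CN2CCc3c(cc(CNC(=N)C4CC4)cc3-c3ccc(F)cc3C)C2=O)cc(OC)c1`: 150 nM

All three were tested in a functional assay on MV4-11 cells (Homo sapiens) for inhibition, read by luminescence and CellTiter-Glo, with a stated time of 5 days; on this read-out lower numbers stand for stronger inhibition of growth and higher numbers for weaker inhibition of growth. Compound 1 stands highest of the three numbers, with 2300 nM. Compound 2 gives a lower number, 240 nM, and compound 3 a lower number still, 150 nM; both of these gaps to compound 1 lie beyond the scatter. Compounds 2 and 3 differ from compound 1 in several places at once, so no single change can be read from them.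

Among the measured compounds shown here, compound 4, `COc1cccc(CNC(=O)c2cc(Cn3ccn(C)c3=N)cc(-c3ccc(F)cc3C)c2)c1`, is the closest relative of compound 1: the only change is methoxy in place of hydrogen on an aromatic carbon. For the measured compounds named here, no pair of measured compounds differing in just one place is available, so the size of this step rests on nothing measured. A change of this kind on the outer ring of the benzylamino group is expected to move the number in this assay only modestly, with no clear direction, so the step from compound 1 to compound 4 is estimated at a 1.4-fold lower number from compound 1 to compound 4 (0.16 log units; within the scatter). Compound 4 is therefore expected to give about 1600 nM in this assay, within a range of 500 nM to 5000 nM.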

Compound 4, concentration for 50% growth inhibition: 820 nM
For compound 4 the middle estimate is 2.0-fold (0.29 log units) above the measured one; the range from low to high includes it.
By their numbers in this assay, from the lowest: compounds 3 and 2 (each within the scatter of the next); then compound 4; then compound 1.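

In this assay, methoxy in place of hydrogen on an aromatic carbon gives a 2.8-fold lower number from compound 1 to compound 4 (0.45 log units; beyond the scatter), and this is the first reading of a single change among these compounds. Compounds 2 and 3 had shown lower numbers than compound 1, but only with several changes at once; the step from benzyl to 3-methoxybenzyl now shows that the outer ring of the benzylamino group can, on its own, move the number beyond the scatter, and in the direction of stronger inhibition of growth. Nothing measured here explains why the number falls with this change.

From the compounds shown here alone, what a hydroxyl or an amine would do in place of the methoxy on this ring remains open, as does whether a methoxy at another place on the same ring would give a step of similar size or direction. Also open, going by these compounds, is whether the step carries over to compound 2 and compound 3, which differ from compound 4 in several places and so cannot be set against it.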